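The source may report more compounds than this note shows. Statements on the series, on what has been measured and on what is new or still open speak of the compounds shown alone.

The account concerns three measured compounds that share one core and a fourth that has not yet been tested. In a functional assay on MCF7 cells (Homo sapiens) for antiproliferative activity, read by MTT assay, with a stated time of 48 h (a lower number here means a stronger inhibitor, a higher number a weaker inhibitor), compound 3 `CSc1nc(-c2ccc(C)cc2)nc2ccc(Cl)cc12` gives 8.64 ug/mL, the highest of the three numbers. Its nearest neighbour is compound 2 `Cc1ccc(-c2nc(NO)c3cc(Cl)ccc3n2)cc1`, which in this assay gives 6.81 ug/mL; the step of a 1.3-fold higher number from compound 2 to compound 3 (0.10 log units; within the scatter) is within the scatter, so the two cannot be ranked. The lowest number belongs to compound 1 `Cc1ccc(-c2nc3ccc(Cl)cc3c(=S)[nH]2)cc1`, which gives 3.35 ug/mL, a gap from compound 3 that lies beyond the scatter.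

Compound 4 `Cc1ccc(-c2nc(Sc3ncccc3[N+](=O)[O-])c3cc(Cl)ccc3n2)cc1` differs from compound 3 in one place: 3-nitropyridin-2-yl in place of methyl on a sulfur. Within the data shown here, no measured step touches this position. Among the measured compounds shown here, the one step in hand, a 1.3-fold higher number from compound 2 to compound 3 (0.10 log units; within the scatter), concerns the group on the aromatic carbon, not the substituent on the sulfur, and it was itself within the scatter. With nothing in the data that speaks for a change at the sulfur, the expectation is for no step beyond the scatter. The number for compound 4 in this assay is therefore estimated at 7 ug/mL, within a range from 2.5 ug/mL to 18 ug/mL, which corresponds to an expected step of a 1.2-fold lower number from compound 3 to compound 4 (0.09 log units; within the scatter).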

Compound 4, half-maximal inhibitory concentration: 3.56 ug/mL
Compound 4: the middle estimate sits 2.0-fold (0.29 log units) above what was measured, within the range that was stated.
By their numbers in this assay, from the lowest: compounds 1, 4, 2 and 3 (each within the scatter of the next, the first and the last beyond it).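

In this assay the exchange on the sulfur gives a 2.4-fold lower number from compound 3 to compound 4 (0.39 log units; beyond the scatter) and so lies beyond the scatter, whereas the earlier step, a 1.3-fold higher number from compound 2 to compound 3 (0.10 log units; within the scatter), concerned the group on the aromatic carbon and could not separate its two compounds. The substituent on this sulfur, whose other neighbour is an aromatic carbon, therefore does register in this series, and replacing methyl with the much larger 3-nitropyridin-2-yl, which brings a six-membered aromatic ring and hydrogen-bond acceptors, gives a lower number rather than a higher one. Nothing in the material shown accounts for this shift.

Since the ring and the nitro group enter together, the compounds shown do not tell which part of 3-nitropyridin-2-yl goes with the lower number. As far as these compounds go, it also remains open how a plain phenyl or unsubstituted pyridin-2-yl on the sulfur would compare with compound 4, and whether a longer chain such as butyl or benzyl would shift the number from that of compound 3 at all.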